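The compounds below may be only part of what the source reports. "The series", "measured", "known", "first", "only" and "open" are said of these compounds alone.

Compounds 1, 2 and 3 share one core and differ only in the ester group. Compound 1 `COC(=O)C(Cn1ccnc1)NC(=O)c1ccc(-c2ccccc2)cc1` carries a methyl ester and in an assay on HL-60 cells for inhibition of cytochrome P450 26A1 (Homo sapiens), read by HPLC, using microsomes and NADPH, with a stated time of 30 min (on this read-out lower numbers stand for stronger inhibition and higher numbers for weaker inhibition), compound 1 gives 370 nM. Compound 2 `CCCOC(=O)C(Cn1ccnc1)NC(=O)c1ccc(-c2ccccc2)cc1` carries a propyl ester and in this assay compound 2 gives 790 nM. Compound 3 `CC(C)OC(=O)C(Cn1ccnc1)NC(=O)c1ccc(-c2ccccc2)cc1` carries an isopropyl ester and in this assay compound 3 gives 540 nM. Of the three numbers, compound 3 holds the middle one, yet its steps to both other compounds stay within the scatter: a 1.5-fold higher number from compound 1 to compound 3 (0.16 log units; within the scatter) and a 1.5-fold lower number from compound 2 to compound 3 (0.17 log units; within the scatter).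

Compound 4 `CC(C)COC(=O)C(Cn1ccnc1)NC(=O)c1ccc(-c2ccccc2)cc1` is the next compound, and the change from compound 3 is isobutyl in place of isopropyl on an oxygen next to a carbonyl group. For the measured compounds named here, the one step that reaches beyond the scatter in this small set is the lengthening of the ester chain, a 2.1-fold higher number from compound 1 to compound 2 (0.33 log units; beyond the scatter), while branching, a 1.5-fold lower number from compound 2 to compound 3 (0.17 log units; within the scatter), changed little. Adding one further carbon to the branched chain therefore is expected to shift the number modestly upward, if at all, in this assay: the expected step is a 1.3-fold higher number from compound 3 to compound 4 (0.11 log units; within the scatter), which may well fall within the scatter.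

The estimate for compound 4 in this assay is 700 nM, with a likely range from 350 nM to 1400 nM.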

Compound 4, half-maximal inhibitory concentration: 970 nM
For compound 4 the middle estimate is 1.4-fold (0.14 log units) below the measured one; low and high end bracket the measured number.
By their numbers in this assay, from the lowest: compounds 1, 3, 2 and 4 (each within the scatter of the next, the first and the last beyond it).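

In this assay, the isobutyl ester shows little separation from its nearest relatives: isobutyl in place of isopropyl gives a 1.8-fold higher number from compound 3 to compound 4 (0.25 log units; within the scatter), and a methyl added to the propyl chain gives a 1.2-fold higher number from compound 2 to compound 4 (0.09 log units; within the scatter). What the new compound adds is a second step from the methyl ester that passes the scatter, a 2.6-fold higher number from compound 1 to compound 4 (0.42 log units; beyond the scatter), alongside a 2.1-fold higher number from compound 1 to compound 2 (0.33 log units; beyond the scatter), so both the propyl and isobutyl esters stand apart from the methyl ester, while the isopropyl ester goes against this pattern with a 1.5-fold higher number from compound 1 to compound 3 (0.16 log units; within the scatter). Nothing at hand explains why these chains give these numbers.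

From the compounds shown here alone, all four esters carry short saturated chains, so it remains open whether a longer chain such as hexyl would continue the upward drift or whether the numbers would level off. Going by these compounds, the response to a benzyl ester, to an amide or to a free carboxylic acid at this position also remains open, and any of these would show whether the ester itself matters or only the size of the chain on its oxygen.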